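Amide Variation on a Flavone Core: Expectation for Compound 3

The source may hold more compounds than are shown below. What is called first, only, known or untested is meant among the compounds shown, and "the series" means these compounds.

Measured compounds:
compound 1, `COc1ccc(C(=O)Nc2cccc(-c3oc4cc(-c5ccc(F)cc5)ccc4c(=O)c3O)c2)c(F)c1`, in a functional assay on GTL 16 cells for antiproliferative activity against GTL 16 cell line (Homo sapiens), read by CCK-8 assay, with a stated time of 72 h (on this read-out higher numbers stand for weaker inhibition and lower numbers for stronger inhibition), compound 1 gives 15300 nM.
compound 2, `O=C(Nc1cccc(-c2oc3cc(-c4ccc(F)cc4)ccc3c(=O)c2O)c1)c1ccc([N+](=O)[O-])cc1`, in this assay compound 2 gives 18200 nM.

Going by the values given here, compound 2 carries the highest of the two numbers so far, but its nearest neighbour is compound 1, and the step of a 1.2-fold higher number from compound 1 to compound 2 (0.08 log units; within the scatter) stays within the scatter, so the two compounds cannot be ordered against each other. Both numbers sit far up the concentration range.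

Compound 3, `CCCc1ccc(C(=O)Nc2cccc(-c3oc4cc(-c5ccc(F)cc5)ccc4c(=O)c3O)c2)cc1`, has not yet been measured. It differs from compound 2 in one place: propyl in place of nitro on an aromatic carbon. Among the compounds with values here, the only measured step that bears on this position is the exchange on the same carbonyl-bound aromatic ring from compound 1 to compound 2, which gave a 1.2-fold higher number from compound 1 to compound 2 (0.08 log units; within the scatter). That single step suggests the substituent on this ring leaves the read-out essentially untouched, though with one step there is little to build on.

Compound 3 is therefore expected to show no step beyond the scatter, a 1.1-fold lower number from compound 2 to compound 3 (0.06 log units; within the scatter). The estimate for compound 3 is 16000 nM, with a plausible range from 6000 nM to 45000 nM.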

Compound 3, half-maximal inhibitory concentration: 20400 nM
Compound 3: the middle estimate sits 1.3-fold (0.11 log units) below what was measured, within the range that was stated.
By their numbers in this assay, from the lowest: compounds 1, 2 and 3 (each within the scatter of the next).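

In this assay, replacing nitro, with its nitrogen, oxygen and 2 hydrogen-bond acceptors, by propyl, with carbon only and no hydrogen-bond acceptors, on the aromatic carbon para to a large group gives a 1.1-fold higher number from compound 2 to compound 3 (0.05 log units; within the scatter) and so leaves the read-out unresolved, even though the two groups differ in their atoms. Going by these compounds alone, the broader exchange of 2-fluoro-4-methoxyphenyl for 4-propylphenyl on the carbonyl carbon gives a 1.3-fold higher number from compound 1 to compound 3 (0.12 log units; within the scatter) and is also unresolved, so compounds 1, 2 and 3 all lie within the scatter of one another, where the earlier compounds offered only a single step. The data shown offer no measurement that accounts for this lack of separation.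

As far as these compounds go, it remains open whether an amine or a carboxylic acid at this aromatic carbon, or a chain longer than propyl, would produce a step beyond the scatter. Also open is whether any change to the amide or the shared core would separate compounds on this read-out, since all the steps shown are confined to the group on the carbonyl carbon.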